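A few compounds are considered here, and "the series" means these few. Any claim that something is new, unique, unknown or untested is made for them only; others in the source may bear on it.

Compound 1 `C=C[C@@](C)(/C=C/c1ccc(Nc2ccc(F)c(F)c2)cc1)CCC=C(C)C`: in a functional assay on NALM-6 cells (Homo sapiens) for cytotoxicity, with a stated time of 72 h (a lower number here means that less compound is needed, a higher number that more compound is needed for the effect), compound 1 gives > 43400 nM, which is a limit of the assay, not a number.
Compound 2 `C=C[C@@](C)(/C=C/c1ccc(Nc2cc(F)c(F)cc2F)cc1)CCC=C(C)C`: in this assay compound 2 gives > 43400 nM, also a limit of the assay.

Compound 1 therefore stands at the edge of what this assay can report, and with the limit of > 43400 nM in this assay, at which 2 of the 2 values shown sit, every value shown sits there. For the measured compounds named here, the one measured step, a step that the two limits leave unreadable from compound 1 to compound 2, has no readable size: both of its ends are limits. Compound 3 `C=C[C@@](C)(/C=C/c1ccc(-c2ccc(Cl)c(Cl)c2)cc1)CCC=C(C)C` differs from compound 1 by 3,4-dichlorophenyl in place of (3,4-difluorophenyl)amino on an aromatic carbon. Going by the values given here, no measured step bears on this change; the only step recorded swaps fluoro for hydrogen and leaves the amino link in place. With both measured compounds at the limit, compound 3 is expected to stay near the limit as well, a step that the limit leaves unreadable from compound 1 to compound 3 that amounts to none beyond the scatter. Compound 3 is estimated at 50000 nM, in the range 15000 nM to 150000 nM, and most likely again reported only as a limit.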

Compound 3, half-maximal effective concentration: > 43400 nM
Compound 3: only a limit was reported (the forecaster's own chance of this, stated with the estimate: 80%); the middle value is on the limit's open side.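

No step can be read from this result: in this assay compound 1 and compound 3 are both reported only as limits, so the change to 3,4-dichlorophenyl has no readable size. The compounds shown leave open what their real values are and how they compare: the limit of > 43400 nM in this assay, at which 3 of the 3 values shown sit.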